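This account rests on a few compounds, and the source may have more. Where it says the series, first, only, none or still open, it means among the compounds named here.

Three compounds share one core and differ only in the group on a saturated chain carbon bound to an aromatic nitrogen. Compound 1 `CC(C)CCn1ccc(-c2ccc(NC3CCOCC3)c(Cl)c2)c(C#N)c1=O` gives 174 nM in a functional assay on CHO cells for positive allosteric modulation of metabotropic glutamate receptor 2 (Homo sapiens), read by scintillation counting and GTPgammaS binding, with a stated time of 30 min; a higher number here means that more compound is needed for the effect, a lower number that less compound is needed. Compound 2 `Cc1cc(Oc2ccc(-c3ccn(CCC(C)C)c(=O)c3C#N)cc2)ccn1` gives 447 nM in this assay, and compound 3 `Cc1cc(Oc2ccc(-c3ccn(CC4CCC4)c(=O)c3C#N)cc2)ccn1` gives 126 nM. Compound 3 has the lowest number of the three; its gap to compound 1 lies within the scatter, while its gap to compound 2 lies beyond it. Going by the values given here, the single step on record, a 3.5-fold lower number from compound 2 to compound 3 (0.55 log units; beyond the scatter), is the only measured change at that carbon. Compound 4 `CCCCn1ccc(-c2ccc(Oc3ccnc(C)c3)cc2)c(C#N)c1=O` is not yet measured; it differs from compound 3 by propyl in place of cyclobutyl on a saturated chain carbon bound to an aromatic nitrogen. Among the compounds with values here, the step from compound 2 to compound 3 bears on this, since it also alters the group at that carbon, but it runs from a branched chain to a ring, whereas the present change runs from a ring to an unbranched chain, and no measured pair shows that. One therefore expects only a small step, a 1.6-fold higher number from compound 3 to compound 4 (0.20 log units; within the scatter), with compound 4 estimated at 200 nM, between 80 nM and 500 nM.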

Compound 4, half-maximal effective concentration: 398 nM
Beside the measured number, compound 4's estimate is 2.0-fold (0.30 log units) below it; low and high end bracket the measured number.
By their numbers in this assay, from the lowest: compounds 3 and 1 (each within the scatter of the next); then compounds 4 and 2 (each within the scatter of the next).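

Read in this assay, the change from cyclobutyl to propyl on a saturated chain carbon bound to an aromatic nitrogen gives a 3.2-fold higher number from compound 3 to compound 4 (0.50 log units; beyond the scatter) and so loses the low number seen with the ring. The unbranched and the branched chain do not separate, with a 1.1-fold lower number from compound 2 to compound 4 (0.05 log units; within the scatter) as the step, so among these three groups on this core cyclobutyl alone stands apart, and both of its steps lie beyond the scatter. No measurement shown here accounts for the ring's lower number.

The compounds shown leave open whether other rings at this carbon, such as cyclopropyl or cyclopentyl, would behave like cyclobutyl, and how an amine or an ether chain would read there. They also leave open whether the cyclobutyl step carries over to the core of compound 1.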